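Swapping Hydroxy for Chloro on the Aryl Ketone

The compounds below may be only part of what the source reports. "The series", "measured", "known", "first", "only" and "open" are said of these compounds alone.

Compound 1 `COc1ccc(C(=O)/C=C/c2cc3ccccc3[nH]c2=O)cc1` and compound 2 `O=C(/C=C/c1cc2ccccc2[nH]c1=O)c1ccc(O)cc1` share one core and differ in a single place. In a functional assay on HCC 2998 cells (Homo sapiens) for cytotoxicity, read by sulforhodamine B assay, with a stated time of 24 h (a higher number here means a weaker inhibitor of growth, a lower number a stronger inhibitor of growth), compound 1 gives 2500 nM and compound 2 gives 4130 nM, so compound 2 sits within the scatter of compound 1; the step of a 1.7-fold higher number from compound 1 to compound 2 (0.22 log units; within the scatter) is the only one measured. Compound 3 `O=C(/C=C/c1cc2ccccc2[nH]c1=O)c1ccc(Cl)cc1` carries chloro in place of hydroxy on an aromatic carbon. Among the compounds with values here, no measured step covers this change; the one known step stayed within the scatter, so no shift beyond the scatter is expected in this assay. Compound 3 is estimated at 3000 nM, between 1000 nM and 10000 nM, a step of a 1.4-fold lower number from compound 2 to compound 3 (0.14 log units; within the scatter).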

Compound 3, concentration for 50% growth inhibition: 6550 nM
The estimate for compound 3 lay 2.2-fold (0.34 log units) below the measured number, and the stated range covers the measured number.
By their numbers in this assay, from the lowest: compounds 1, 2 and 3 (each within the scatter of the next, the first and the last beyond it).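

Chloro in place of hydroxy at this position gives a 1.6-fold higher number from compound 2 to compound 3 (0.20 log units; within the scatter) in this assay even though the hydrogen-bond donor and acceptor of hydroxy are gone. Chloro in place of methoxy gives a 2.6-fold higher number from compound 1 to compound 3 (0.42 log units; beyond the scatter) and is the first step at this position to lie beyond the scatter, so the choice of group here can register in this assay. No available evidence bears on what lies behind these steps. As far as these compounds go, how an amine or a carboxylic acid at this position would compare with chloro, hydroxy and methoxy remains open.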